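The source may report more compounds than this note shows. Statements on the series, on what has been measured and on what is new or still open speak of the compounds shown alone.

Of the compounds shown here, three built on one shared core have been measured in an assay on HL-60 cells for agonist activity at vitamin D3 receptor (Homo sapiens), with a stated time of 96 h; a higher number here means that more compound is needed for the effect, a lower number that less compound is needed. Compound 1 `CCC(CC)(c1ccc(OCC(O)C(C)(C)C)c(C)c1)c1ccc(C(=O)N[C@@H](C)CO)n1C` gives 570 nM. Compound 2 `CCC(CC)(c1ccc(OCC(O)C(C)(C)C)c(C)c1)c1ccc(C(=O)N[C@H](CO)CCO)n1C` gives 200 nM, and compound 3 `CCn1c(C(=O)N[C@H](CO)CCO)ccc1C(CC)(CC)c1ccc(OCC(O)C(C)(C)C)c(C)c1` gives 110 nM. Compound 2 thus stands second highest of the three numbers; its nearest neighbour is compound 3, within the scatter of it, while the step of a 2.9-fold lower number from compound 1 to compound 2 (0.45 log units; beyond the scatter) sets it further from compound 1. The step of a 1.8-fold lower number from compound 2 to compound 3 (0.26 log units; within the scatter) concerns the saturated chain carbon bound to the aromatic nitrogen and does not touch the amide.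

Compound 4 `CCC(CC)(c1ccc(OCC(O)C(C)(C)C)c(C)c1)c1ccc(C(=O)NCCC(=O)O)n1C` has not yet been measured. It differs from compound 2 by 2-carboxyethyl in place of 3-hydroxy-1-(hydroxymethyl)propyl on an amide-type nitrogen. For the measured compounds named here, the one measured step that bears on this part of the molecule is a 2.9-fold lower number from compound 1 to compound 2 (0.45 log units; beyond the scatter), in which a hydroxymethyl group entered the chain two bonds along from the amide-type nitrogen and the number fell. Compound 4 moves the other way, removing the hydroxyl groups and bringing in a carboxylic acid, so a step back toward or past the number of compound 1 in this assay is expected. The expected step is a 3.5-fold higher number from compound 2 to compound 4 (0.54 log units; beyond the scatter). Compound 4 is therefore estimated at 700 nM in this assay, with a range from 250 nM to 2000 nM.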

Compound 4, half-maximal effective concentration: 1600 nM
Compound 4: the middle estimate sits 2.3-fold (0.36 log units) below what was measured; the measured number falls inside the stated range.
By their numbers in this assay, from the lowest: compounds 3 and 2 (each within the scatter of the next); then compound 1; then compound 4.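

In this assay, the step of an 8.0-fold higher number from compound 2 to compound 4 (0.90 log units; beyond the scatter) shows that the group on the amide-type nitrogen can by itself move the number well beyond the scatter, and upward as well as downward. For the compounds shown here, the step of a 2.8-fold higher number from compound 1 to compound 4 (0.45 log units; beyond the scatter) adds that 2-carboxyethyl stands above 1-(hydroxymethyl)ethyl as well, so the earlier fall on adding a hydroxymethyl group was only one part of what this position can do, and the carboxylic acid end lies at the high end of the numbers so far. Nothing given here accounts for this rise in the number.

Because 3-hydroxy-1-(hydroxymethyl)propyl and its defined stereocentre leave in the same step that 2-carboxyethyl enters, the compounds shown leave open whether the carboxylic acid itself, the loss of the hydroxyl groups or the loss of the branched chain carries the change. As far as these compounds go, a straight 3-hydroxypropyl chain, a methyl ester or a primary amide in place of the carboxylic acid on the same nitrogen would separate these readings, and whether the ethyl group on the aromatic nitrogen of compound 3 would make any difference with the carboxylic acid also remains open.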